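The compounds below may be only part of what the source reports. "The series", "measured", "known", "first", "only" and "open" are said of these compounds alone.

Measured so far:
- compound 1 `FC(F)(F)c1cnc(N2CCC(NC(=S)Nc3cccnc3)CC2)c(Cl)c1`: 1100 nM
- compound 2 `FC(F)(F)Oc1cccc(Oc2ccnc(N3CCC(NC(=S)Nc4cccnc4)CC3)c2Cl)c1`: 89 nM

Both compounds were tested in an assay on membranes from brain for binding affinity to Lysophosphatidylserine lipase ABHD12 (Mus musculus), read by fluorescence, with a stated time of 20 min; on this read-out higher numbers stand for weaker inhibition and lower numbers for stronger inhibition. Compound 1 gives 1100 nM, and compound 2 gives 89 nM; compound 1 holds the higher number of the two, which on this read-out means weaker inhibition, and the gap between them is far wider than the usual scatter of repeated measurements. Going by the values given here, no single-point step between these two compounds is recorded, since they differ in more than one place.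

Compound 3 `S=C(Nc1cccnc1)NC1CCN(c2ncccc2Cl)CC1` has not been measured. It differs from compound 1 in one place: hydrogen in place of trifluoromethyl on an aromatic carbon. The trifluoromethyl group, which sits two atoms from the ring nitrogen, meta to a chloro group and para to a large group, is simply gone, leaving a hydrogen in its stead.

Nothing in the two measured compounds shows the effect of removing this group. Taking away a substituent without adding anything in its place is expected to cost some inhibition, so the estimated step of a 2.7-fold higher number from compound 1 to compound 3 (0.44 log units; beyond the scatter) points toward a higher number, of modest size. Compound 3 is therefore estimated at 3000 nM, with a plausible range from 1000 nM to 9000 nM.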

Compound 3, half-maximal inhibitory concentration: > 5000 nM
Compound 3: no number, only a limit (the forecaster's own chance of this, stated with the estimate: 15%); at least 1.6-fold (0.22 log units) between middle value and limit.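

In this assay compound 3 gives > 5000 nM, which is a limit of the assay and not a number. Replacing the trifluoromethyl group, two atoms from the ring nitrogen, with hydrogen gives an at least 4.5-fold higher number from compound 1 to compound 3 (0.65 log units; beyond the scatter), so this single position on the core of compound 1 clearly matters for inhibition, something the two earlier compounds could not show because they differ in more than one place: the limit of > 5000 nM in this assay, at which 1 of the 3 values shown sits.

The compounds shown leave open whether a smaller group at this position, such as a methyl, a chloro or a nitrile, would keep the inhibition of compound 1 or lose it as hydrogen does, since trifluoromethyl and hydrogen are the only two groups compared here. They also leave open how far the true value of compound 3 lies past its limit, and whether removing a group at this position would have a similar effect on a compound carrying the larger substituent of compound 2.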